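A few compounds are considered here, and "the series" means these few. Any claim that something is new, unique, unknown or untested is made for them only; others in the source may bear on it.

Of the compounds shown here, three built on a shared core have been measured in a physicochemical assay for lipophilicity, measured as octanol-water partition; on this read-out higher numbers stand for higher lipophilicity and lower numbers for lower lipophilicity. Compound 1 `Cc1ccc(-c2c(C#N)[n+]([O-])c3ccccc3[n+]2[O-])cc1` gives 2.09. Compound 2 `COc1ccc(-c2c(C#N)[n+]([O-])c3ccccc3[n+]2[O-])cc1` gives 1.58 in this assay. The structural change between them is methoxy in place of methyl on an aromatic carbon and the step it made is a number 0.51 log units lower from compound 1 to compound 2 (beyond the scatter). Compound 3 `Cc1ccc(-c2c(C#N)[n+]([O-])c3cc(C)c(C)cc3[n+]2[O-])cc1` gives 2.57 in this assay, the highest of the three numbers, lying beyond the scatter above both compound 1 and compound 2. The difference between the core of compound 1 and the core of compound 3 is not broken down here.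

Compound 4 `COc1ccc(-c2c(C#N)[n+]([O-])c3cc(C)c(C)cc3[n+]2[O-])cc1` has not yet been measured. Among the compounds with values here, it differs from compound 3 by methoxy in place of methyl on an aromatic carbon, the same change as the one from compound 1 to compound 2, and the surroundings of the place are described in the same words in both cases. The step from compound 3 to compound 4 is therefore expected to be about a number 0.51 log units lower from compound 3 to compound 4 (beyond the scatter) because the measured step was a number 0.51 log units lower from compound 1 to compound 2 (beyond the scatter). Compound 4 is accordingly estimated at 2.06, most likely between 1.8 and 2.35.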

Compound 4, partition coefficient: 2.06
Compound 4: the middle estimate sits on the measured number at the digits printed, and the stated range covers the measured number.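

In this assay, putting methoxy in place of methyl gives a number 0.51 log units lower from compound 3 to compound 4 (beyond the scatter) and on the other core gives a number 0.51 log units lower from compound 1 to compound 2 (beyond the scatter) as well, so the change from 4-methylphenyl to 4-methoxyphenyl carries over between these two cores with a step of the same size. This is a single change compared on a single pair of cores, which shows agreement in this one case and does not establish a rule for other cores or other groups in the series. The data offer no measurement that could explain the size of the step.

The compounds shown have only methyl and methoxy at this place, so it remains open how an ethoxy group, an amine or a carboxylic acid there would behave on either core. On these data alone, it also remains open whether the same step would appear on a core carrying other groups, such as chlorine.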